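A few compounds are considered here, and "the series" means these few. Any claim that something is new, unique, unknown or untested is made for them only; others in the source may bear on it.

Compound 1 `COc1cc(OC)c(/C=C/C(=O)/C=C/c2cc3ccccc3nc2Cl)c(OC)c1`: > 10000 nM
Compound 2 `COc1ccc(/C=C/C(=O)/C=C/c2cc3ccccc3nc2Oc2ccc(Br)cc2)c(OC)c1`: > 10000 nM

Both compounds were tested in a functional assay on 4T1 cells (Mus musculus) for cytotoxicity, read by MTT assay, with a stated time of 48 h (a lower number here means a stronger inhibitor, a higher number a weaker inhibitor), and neither gave a number. In that assay compound 2 reaches only a limit, > 10000 nM. Compound 1 likewise reaches only a limit, > 10000 nM. The whole record so far is therefore (the limit of > 10000 nM in this assay, at which 2 of the 2 values shown sit).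

Compound 3 `COc1cc(OC)c(/C=C/C(=O)/C=C/c2cc3ccccc3nc2Oc2ccc(Br)cc2)c(OC)c1` follows from compound 2 through one change: methoxy in place of hydrogen on an aromatic carbon. In words, a methoxy replaces a hydrogen on an aromatic carbon, which turns 2,4-dimethoxyphenyl into 2,4,6-trimethoxyphenyl.

Within the data shown here, no measured pair in this assay shows what this change does, so its size has to be judged without a direct precedent. No step beyond the usual scatter is expected, and the most likely result is that compound 3 again reaches only a limit. The expected change is a step that the limit leaves unreadable from compound 2 to compound 3, although the limit on compound 2 leaves a real gain possible. The estimated value for compound 3 is 12000 nM, with an expected range of 3000 nM to 30000 nM.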

Compound 3, half-maximal inhibitory concentration: > 10000 nM
Compound 3 ended at the assay's limit (the forecaster's own chance of this, stated with the estimate: 65%); the middle value lies beyond the limit too.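

In this assay compound 3 gives > 10000 nM, which is a limit of the assay. Its steps from compound 2 and from compound 1 therefore cannot be read. The compounds shown leave open whether any of them would give an actual number there, and what either change does to the value: the limit of > 10000 nM in this assay, at which 3 of the 3 values shown sit.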